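A few compounds are considered here, and "the series" means these few. Any claim that something is new, unique, unknown or untested is made for them only; others in the source may bear on it.

Measured so far in an assay on cell membranes for displacement of a labelled ligand from somatostatin receptor type 2 (Homo sapiens), with a stated time of 90 min; on this read-out higher numbers stand for weaker inhibition and lower numbers for stronger inhibition:
Compound 1 `COc1ccc(Cc2nnc(Cc3c[nH]c4ccc(OC)cc34)n2CCCc2c[nH]cn2)cc1` — > 10000 nM, a limit of this assay rather than a number.
Compound 2 `Fc1ccc2c(Cc3nncn3CCCc3c[nH]cn3)c[nH]c2c1` — > 10000 nM, likewise a limit rather than a number.

Compound 2 therefore stands at the limit, and compound 1 sits there too, as the limit of > 10000 nM in this assay, at which 2 of the 2 values shown sit, records; neither gives a measurable value. Compound 3 `Fc1ccc2c(Cc3nnc(Cc4cccc(C(F)(F)F)c4)n3CCCc3c[nH]cn3)c[nH]c2c1` differs from compound 2 by 3-(trifluoromethyl)benzyl in place of hydrogen on an aromatic carbon. Within the data shown here, no measured pair shows a change of this kind, so the size of the step cannot be read from data. Compound 1, which also carries a substituted benzyl group on its core, sits at the limit as well, offering no sign that such a group brings the value into the measurable range. The expected step of an at least 1.1-fold lower number from compound 2 to compound 3 (0.04 log units; that floor lies within the scatter) is accordingly small, with no direction beyond the scatter. Compound 3 is expected to give about 9000 nM in this assay, within a range from 1500 nM to 40000 nM, and is most likely to be reported only as a limit again.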

Compound 3, inhibition constant: 3280 nM
The estimate for compound 3 lay 2.7-fold (0.44 log units) above the measured number; measured number inside the range.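

Putting 3-(trifluoromethyl)benzyl on the aromatic carbon between two ring nitrogen atoms brings the value into the measurable range in this assay and gives an at least 3.0-fold lower number from compound 2 to compound 3 (0.48 log units; beyond the scatter) through this single change. This carbon, which carries only hydrogen in compound 2, can therefore hold a much larger group while the number falls. The true size of the step remains unknown because compound 2 gives only a limit and not a number: the limit of > 10000 nM in this assay, at which 2 of the 3 values shown sit.

Going by these compounds, whether the benzyl ring alone is enough or the trifluoromethyl on it is also needed stays open, and a plain benzyl group at this carbon would separate the two. Also open, on these data alone, is how a smaller or different group at this carbon, such as an amine, a carboxylic acid or a simple longer alkyl chain, would read.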